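The compounds below may be only part of what the source reports. "The series", "measured", "known", "first", "only" and "open" are said of these compounds alone.

Measured compounds:
compound 1, `Cc1cccc(NC(=O)/C(C#N)=C/c2cc(O)c(O)c([N+](=O)[O-])c2)c1`, gives 5.6 ug/mL in a functional assay on BGC-823 cells (Homo sapiens) for antiproliferative activity, read by MTT assay; a higher number here means a weaker inhibitor, a lower number a stronger inhibitor;
compound 2, `N#C/C(=C\c1cc(O)c(O)c([N+](=O)[O-])c1)C(=O)Nc1cccc(Cl)c1`, gives > 100 ug/mL in this assay, which is a limit of the assay rather than a number.

Compound 2 therefore stands at the edge of what this assay reports, as the limit of > 100 ug/mL in this assay, at which 1 of the 2 values shown sits, marks. Among the compounds with values here, the only measured step in the set, an at least 17-fold higher number from compound 1 to compound 2 (1.25 log units; beyond the scatter), shows that exchanging the group on the aromatic carbon of the ring attached to the amide nitrogen can shift the read-out a great deal. Compound 3, `N#C/C(=C\c1cc(O)c(O)c([N+](=O)[O-])c1)C(=O)Nc1ccccc1Cl`, differs from compound 2 by 2-chlorophenyl in place of 3-chlorophenyl on an amide-type nitrogen, so the chlorine stays but changes position on that ring. Within the data shown here, no measured step moves a chlorine in this way, so the direction of the change cannot be read from the data; the measured step only says that alterations on this ring tend to matter. The step from compound 2 to compound 3 is expected to be an at least 1.6-fold lower number from compound 2 to compound 3 (0.22 log units; that floor lies within the scatter), a return toward a measurable number. Compound 3 is estimated at 60 ug/mL, within 10 ug/mL to 200 ug/mL, with a sizeable chance that only a limit is reported again.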

Compound 3, half-maximal inhibitory concentration: 10.5 ug/mL
The estimate for compound 3 lay 5.7-fold (0.76 log units) above the measured number; the range from low to high includes it.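

Moving the chlorine from 3-chlorophenyl to 2-chlorophenyl on the amide-type nitrogen, with the same atoms joined differently, gives an at least 9.5-fold lower number from compound 2 to compound 3 (0.97 log units; beyond the scatter), so in this assay the place of the chlorine on this ring matters and not merely its presence. Compound 2 remains a limit of the assay and not a number, so this step gives only a floor for the true size of the change: the limit of > 100 ug/mL in this assay, at which 1 of the 3 values shown sits. A chlorine on this ring is also compatible with a measurable number, since 2-chlorophenyl in place of 3-methylphenyl gives a 1.9-fold higher number from compound 1 to compound 3 (0.27 log units; within the scatter), which leaves compound 1 and compound 3 indistinguishable here, and the drop seen for compound 2 therefore goes with the 3-chlorophenyl group specifically, not with chlorine in general.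

The compounds shown do not say why the place of the chlorine matters, or whether moving the methyl group of compound 1 around the ring would have a similar effect. Also open, from the compounds shown here alone, is what a plain phenyl ring, or a ring carrying a methoxy group or an amine, would give on the same core.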